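Oxime replaced by acetyl on the anilide ring: compound 4

The source may hold more compounds than are shown below. What is called first, only, known or untested is meant among the compounds shown, and "the series" means these compounds.

Measured in a functional assay on the whole organism (strain albino) for inhibition, with Rattus norvegicus as the target, read by paw edema, with stated times of 30 min and 1 h, at a dose of 0.28 mmol/kg by the oral route; a lower number here means less inhibition, a higher number more inhibition at the dose given (going by the name of the read-out):
compound 1 `COc1cc(-c2nnc(SCC(=O)Nc3ccc(/C(C)=N/O)cc3)n2-c2ccccc2)cc(OC)c1OC` gives 59%
compound 2 `COc1ccc(-c2nnc(SCC(=O)Nc3ccc(/C(C)=N/O)cc3)n2-c2ccccc2)cc1` gives 45%
compound 3 `COc1ccc(-c2nnc(SCC(=O)Nc3ccc(/C(C)=N/O)cc3)n2-c2ccccc2)cc1OC` gives 57%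

Compound 2 has the lowest number of the three. The nearest step is a number 12 percentage points higher from compound 2 to compound 3 (beyond the scatter); the widest gap, read in the other direction, is a number 14 percentage points lower from compound 1 to compound 2 (beyond the scatter); the third step, a number 2 percentage points lower from compound 1 to compound 3 (within the scatter), is small.

Compound 4 `COc1ccc(-c2nnc(SCC(=O)Nc3ccc(C(C)=O)cc3)n2-c2ccccc2)cc1` differs from compound 2 by a group of 3 heavy atoms (2 carbon, 1 oxygen; no ring) in place of a group of 4 heavy atoms (2 carbon, 1 nitrogen, 1 oxygen; no ring), on an aromatic carbon. Going by the values given here, every measured step concerns the methoxy pattern on the other aryl ring; all three measured compounds carry the same group at the position changed here, so no measured step bears on this change. A step of uncertain direction and within the scatter is therefore expected, a number 3 percentage points lower from compound 2 to compound 4 (within the scatter). Compound 4 is expected to give about 42%, in the range 25% to 58%.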

Compound 4, a percentage reported as inhibition, in the whole organism at one dose (the size of the read-out at that dose, not a potency): 29%
Compound 4: middle estimate off by 13 percentage points, on the high side; the range from low to high includes it.
By their numbers in this assay, from the lowest: compound 4; then compound 2; then compounds 3 and 1 (each within the scatter of the next).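

In this assay, the position on the anilide ring, constant across compounds 1 to 3, proves able to move the read-out: acetyl in place of the oxime gives a number 16 percentage points lower from compound 2 to compound 4 (beyond the scatter). Activity in this set therefore depends on more than the methoxy pattern on the other aryl ring. Nothing available explains the step, and the oxime's hydrogen-bond donor cannot be singled out from the rest of the change.

Open, as far as these compounds go, is whether an amine or a carboxylic acid here would match the oxime or the acetyl. Also open, from the compounds shown here alone, is whether the acetyl step carries over to the 3,4,5-trimethoxyphenyl series.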